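The compounds below may be only part of what the source reports. "The series", "measured", "known", "first", "only" and "open" are said of these compounds alone.

Compounds measured so far in a functional assay on CHO cells for inhibition of metabotropic glutamate receptor 5 (Rattus norvegicus), read by FLIPR and calcium flux; a lower number here means a stronger inhibitor, a higher number a weaker inhibitor:

- Compound 1 `COc1cccc(-c2ccc3ccc(C)nc3c2)c1`: compound 1 gives 860 nM
- Compound 2 `COCc1cccc(-c2ccc3ccc(C)nc3c2)c1`: compound 2 gives 5800 nM
- Compound 3 `Cc1ccc2ccc(-c3ccccc3C#N)cc2n1`: compound 3 gives 9800 nM

All three share the same core and differ only in the group carried on the attached benzene ring. Compound 3, which carries a cyano group, stands at the highest number of the three in this assay; its nearest neighbour is compound 2, and that gap is within the scatter, while the gap to compound 1 is beyond it. Among the measured compounds shown here, the one single-change step available is a 6.7-fold higher number from compound 1 to compound 2 (0.83 log units; beyond the scatter).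

Compound 4 `COc1ccccc1-c1ccc2ccc(C)nc2c1` arises from compound 3 by one change: methoxy in place of cyano on an aromatic carbon. For the measured compounds named here, no measured step covers this exchange at this place; the step from compound 1 to compound 2 involves methoxy, but on a different carbon of the ring and against methoxymethyl, not cyano. It therefore gives no direction for the change in this assay, and the expectation must stay wide. The estimated step is a 1.6-fold lower number from compound 3 to compound 4 (0.21 log units; within the scatter), leaning slightly toward a lower number. Compound 4 is expected to give about 6000 nM in this assay, with a range from 1500 nM to 25000 nM.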

Compound 4, half-maximal inhibitory concentration: 4200 nM
Compound 4: middle estimate off by 1.4-fold (0.15 log units), on the high side, within the range that was stated.
By their numbers in this assay, from the lowest: compound 1; then compounds 4, 2 and 3 (each within the scatter of the next, the first and the last beyond it).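

In this assay, among the compounds shown here, the exchange at this place, on an aromatic carbon ortho to a large group, gives a 2.3-fold lower number from compound 3 to compound 4 (0.37 log units; beyond the scatter) and so shows for the first time that the number responds to the group on this carbon. The response appears even though cyano and methoxy match in their counts of heavy atoms and hydrogen-bond acceptors, so those counts alone do not settle the number here. Methoxy also stands on a different carbon of the ring in compound 1, which gives 860 nM while compound 4 gives 4200 nM in this assay, so the same group reads differently at the two places, and nothing measured here explains this step or that difference.

The compounds shown leave open how an amine, a carboxylic acid or a longer chain such as ethoxy would read on this same carbon, and so how far the number can move at this place. They also leave open whether cyano would give a similar step on the carbon that carries methoxy in compound 1.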